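The source may hold more compounds than are shown below. What is called first, only, known or untested is meant among the compounds shown, and "the series" means these compounds.

Compound 1 `COc1ccc(Nc2ccc3c(c2)C(=O)N(C2CCC(=O)NC2=O)C3=O)cc1`: 29%
Compound 2 `CCOC(=O)c1ccc(Nc2ccc3c(c2)C(=O)N(C2CCC(=O)NC2=O)C3=O)cc1`: 5%
Compound 3 `CCCCCc1ccc(Nc2ccc3c(c2)C(=O)N(C2CCC(=O)NC2=O)C3=O)cc1`: 12%

These three compounds share one core and differ in a single group. In an assay on FRT-Jurkat cells for inhibition of nuclear factor NF-kappa-B complex (Homo sapiens), read by flow cytometry, with a stated time of 24 h, tested at 10 uM (a lower number here means less inhibition, a higher number more inhibition at the concentration tested (going by the name of the read-out)), compound 1 stands highest of the three; compound 3 is nearest and compound 2 furthest, and both steps lie beyond the scatter: a number 17 percentage points lower from compound 1 to compound 3 (beyond the scatter) and a number 24 percentage points lower from compound 1 to compound 2 (beyond the scatter). Compound 4 `CN(c1ccccc1)c1ccc2c(c1)C(=O)N(C1CCC(=O)NC1=O)C2=O` has not been measured. It differs from compound 1 by methyl(phenyl)amino in place of (4-methoxyphenyl)amino on an aromatic carbon. For the measured compounds named here, no measured step alters the same place, so the bearing of the known steps is indirect: they only show that each departure from compound 1 so far has lowered the read-out modestly. A modest fall is therefore expected in this assay for compound 4, estimated at 15% with a range from 0% to 35%, which would mean a step of a number 14 percentage points lower from compound 1 to compound 4 (beyond the scatter).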

Compound 4, a percentage reported as inhibition, at one concentration (the size of the read-out at that concentration, not a potency): -2%
Compound 4: the middle estimate sits 17 percentage points above what was measured; the whole stated range lies above it.
By their numbers in this assay, from the lowest: compounds 4, 2 and 3 (each within the scatter of the next, the first and the last beyond it); then compound 1.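

In this assay, for the compounds shown here, the step of a number 31 percentage points lower from compound 1 to compound 4 (beyond the scatter) is larger than either earlier step, and it is the first to alter the nitrogen itself: a methyl replaces the amine hydrogen, leaving no hydrogen-bond donor in the group. The same change also removes the methoxy, so two edits are bundled into one step. Nothing measured here explains the fall. Still open, on these data alone, is which edit matters: plain phenylamino would test loss of the methoxy alone, and (4-methoxyphenyl)(methyl)amino would test methylation of the nitrogen alone.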